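Compound 4: trading the 2-oxoimidazolidin-1-yl group for an imidazole

The compounds below may be only part of what the source reports. "The series", "measured", "known", "first", "only" and "open" are said of these compounds alone.

Values in an ADME assay on microsomes from liver (Rattus norvegicus) for metabolic stability; on this read-out higher numbers stand for a longer-lived compound and lower numbers for a shorter-lived compound:
- compound 1 `CC(C)C(Cc1ncc[nH]1)c1ccc(-c2ccc3cccc(F)c3c2)[nH]c1=O` gives < 0.0667 h as a limit
- compound 2 `CC(C)C(c1noc(=O)[nH]1)c1ccc(-c2ccc3cccc(F)c3c2)[nH]c1=O` gives > 3 h as a limit
- compound 3 `CC(C)C(c1ccc(-c2ccc3cccc(F)c3c2)[nH]c1=O)N1CCNC1=O` gives 0.283 h as a true number

Compound 3 is the only one of the three with a true number. The measured steps place it in the middle, with an at least 4.2-fold higher number from compound 1 to compound 3 (0.62 log units; beyond the scatter) on one side and an at least 10-fold lower number from compound 2 to compound 3 (1.02 log units; beyond the scatter) on the other.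

Compound 4 `Cc1c[nH]c(C(c2ccc(-c3ccc4cccc(F)c4c3)[nH]c2=O)C(C)C)n1` differs from compound 3 in one place, on a saturated chain carbon bound to an aromatic carbon and a saturated chain carbon: 4-methyl-1H-imidazol-2-yl in place of 2-oxoimidazolidin-1-yl on a saturated chain carbon bound to an aromatic carbon and a saturated chain carbon in the counted difference. In words, 4-methyl-1H-imidazol-2-yl stands in place of 2-oxoimidazolidin-1-yl.

Within the data shown here, no measured step makes this exact swap. The closest guide is compound 1, whose (1H-imidazol-2-yl)methyl group also holds a five-membered aromatic ring with 2 hetero atoms. Replacing that group gave an at least 4.2-fold higher number from compound 1 to compound 3 (0.62 log units; beyond the scatter) and also an at least 44-fold higher number from compound 1 to compound 2 (1.65 log units; beyond the scatter) in the two measured cases. Both steps leave compound 1 lowest, so bringing an imidazole into compound 3 should lower the number, although the two imidazole groups are not the same. A modest fall is therefore expected in this assay as the estimated 2.6-fold lower number from compound 3 to compound 4 (0.41 log units; beyond the scatter) for this change. For compound 4 the estimate is 0.11 h with an expected range from 0.04 h to 0.3 h in this read-out.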

Compound 4, half-life: < 0.0667 h
Compound 4 was reported as a limit (the forecaster's own chance of this, stated with the estimate: 35%); middle value at least 1.6-fold (0.21 log units) from the limit.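

In this assay, putting 4-methyl-1H-imidazol-2-yl in place of 2-oxoimidazolidin-1-yl on this saturated chain carbon gives an at least 4.2-fold lower number from compound 3 to compound 4 (0.62 log units; beyond the scatter). Set against the five-membered aromatic ring with 3 hetero atoms, the new group gives an at least 44-fold lower number from compound 2 to compound 4 (1.65 log units; beyond the scatter), so two rings of the same size and the same heavy-atom count in the group lie far apart on this read-out. The short half-life is therefore not tied to the (1H-imidazol-2-yl)methyl group alone: among the compounds shown, both groups holding an imidazole ring end at the low limit of the assay, while the groups in compound 2 and compound 3 stand higher.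

Going by these compounds, the step from compound 1 to compound 4 cannot be read, because both values are limits and neither is a true number: the limit of < 0.0667 h in this assay, at which 2 of the 4 values shown sit. How far either imidazole compound really falls short therefore stays open, as does what a carboxylic acid or an amine would do on the same carbon in this assay.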